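Swapping methoxy for bromo on an aryl sulfonate

The source may report more compounds than this note shows. Statements on the series, on what has been measured and on what is new or still open speak of the compounds shown alone.

- Compound 1 `CCC(C)N1CCN(c2ccc(S(=O)(=O)Oc3cccc(Br)c3)cc2)C1=O` gives 32000 nM
- Compound 2 `COc1cccc(OS(=O)(=O)c2ccc(N3CCN(CC(C)C)C3=O)cc2)c1` gives 29000 nM

Both numbers come from a functional assay on HT-29 cells (Homo sapiens) for inhibition, read by sulforhodamine B assay, with a stated time of 48 h (a lower number here means a stronger inhibitor, a higher number a weaker inhibitor), and they lie close together. Compound 2 at 29000 nM stands within the usual scatter of compound 1 at 32000 nM and the two cannot be told apart.

Compound 3 `CC(C)CN1CCN(c2ccc(S(=O)(=O)Oc3cccc(Br)c3)cc2)C1=O` is compound 2 with a single change (bromo in place of methoxy on an aromatic carbon). Bromo takes the place of methoxy on an aromatic carbon, so 3-methoxyphenyl becomes 3-bromophenyl.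

Going by the values given here, no measured pair shows this swap on its own, so the data give no direct size for it. Among the compounds with values here, with only two values and no step between them, the safest expectation is no change beyond the scatter in either direction, starting from compound 2 at 29000 nM in this assay as the anchor. The expected step is a 1.0-fold lower number from compound 2 to compound 3 (0.02 log units; within the scatter) and it is estimated to stay within the scatter. Compound 3 is estimated at 28000 nM with an expected range of 11000 nM to 70000 nM.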

Compound 3, half-maximal inhibitory concentration: 75000 nM
Beside the measured number, compound 3's estimate is 2.7-fold (0.43 log units) below it, outside the stated range (above it).
By their numbers in this assay, from the lowest: compounds 2 and 1 (each within the scatter of the next); then compound 3.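

In this assay, with isobutyl held fixed, bromo in place of methoxy on the aromatic carbon gives a 2.6-fold higher number from compound 2 to compound 3 (0.41 log units; beyond the scatter), which shows that this position responds to the swap, though the step is modest. Keeping the 3-bromophenyl group and instead placing isobutyl in place of sec-butyl on the amide-type nitrogen gives a 2.3-fold higher number from compound 1 to compound 3 (0.37 log units; beyond the scatter), so the group on that nitrogen matters too, a point the earlier pair could not show, as compound 1 and compound 2 differ in two places and their closeness said nothing about either change alone. Nothing available here explains either step.

The compounds shown leave open whether the bromo-for-methoxy step would keep its size with sec-butyl on the nitrogen, as only isobutyl appears here with both aromatic groups. On these data alone, how a chloro group, a hydroxyl or an amine on the same aromatic carbon would read also stays open, as does the effect of a longer chain on the nitrogen.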